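Swapping chloro for fluoro on a second core

The source may hold more compounds than are shown below. What is called first, only, known or untested is meant among the compounds shown, and "the series" means these compounds.

Measured compounds:
- compound 1, `Clc1ccc(-c2n[nH]cc2N2CCCNCC2)cc1`: 498 nM
- compound 2, `Fc1ccc(-c2n[nH]cc2N2CCCNCC2)cc1`: 1810 nM
- compound 3, `Clc1cccc(-c2n[nH]cc2N2CCNCC2)c1`: 806 nM

The three measured compounds were tested in an assay on isolated protein for binding affinity to 5-hydroxytryptamine receptor 3A (Homo sapiens); on this read-out higher numbers stand for weaker inhibition and lower numbers for stronger inhibition. Compound 1 and compound 2 share one core and differ by fluoro in place of chloro on an aromatic carbon. That change gave a 3.6-fold higher number from compound 1 to compound 2 (0.56 log units; beyond the scatter). Compound 3 has a different core; how the two cores differ is not broken down here. In this assay compound 3 sits between the other two: near compound 1, further from compound 2.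

Compound 4, `Fc1cccc(-c2n[nH]cc2N2CCNCC2)c1`, is not yet measured. It differs from compound 3 by fluoro in place of chloro on an aromatic carbon. Among the compounds with values here, this is the same kind of change as the one from compound 1 to compound 2, though not the same: in compound 1 the fluoro sits para to a large group, whereas in compound 3 it sits meta to a large group. Because that earlier change gave a 3.6-fold higher number from compound 1 to compound 2 (0.56 log units; beyond the scatter), a step of similar size is expected here, giving an estimated 3.3-fold higher number from compound 3 to compound 4 (0.53 log units; beyond the scatter). Compound 4 is therefore expected to show about 2700 nM, with a likely range from 1200 nM to 6000 nM.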

Compound 4, inhibition constant: > 10000 nM
Compound 4 was reported as a limit; the forecaster's own chance of this, stated with the estimate: 3%; middle value at least 3.7-fold (0.56 log units) from the limit.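

In this assay compound 4 gives > 10000 nM, which is a limit of the assay and not a number: the limit of > 10000 nM in this assay, at which 1 of the 4 values shown sits.

Fluoro in place of chloro gave a higher number on both cores, so the direction of the change carried over, but its size did not, with an at least 12-fold higher number from compound 3 to compound 4 (1.09 log units; beyond the scatter): the same change on two cores in this assay, a 3.6-fold higher number (0.56 log units; beyond the scatter) from compound 1 to compound 2 and an at least 12-fold higher number (1.09 log units; beyond the scatter) from compound 3 to compound 4, at least 3.4-fold (0.53 log units) apart, beyond the scatter of two such steps

This shows that the size of the step on one core does not fix its size on the other, but it does not show why: the two pairs differ both in their core and in the place of the halogen, and the full size of the second step remains unknown.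

The compounds shown leave open whether the core or the place of the halogen matters more, which chloro and fluoro pairs at matching places on both cores could help to separate. They also leave open how a different group on that aromatic carbon, such as methoxy or a nitrile, would compare with chloro.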